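The source may hold more compounds than are shown below. What is called first, only, known or untested is meant among the compounds shown, and "the series" means these compounds.

The measured compounds and their values:

Compound 1, `CC(C)COC(=O)Nc1ccc([Se][Se]c2ccc(NC(=O)OCC(C)C)cc2)cc1`: 39800 nM
Compound 2, `CCCOC(=O)Nc1ccc([Se]C#N)cc1`: 38400 nM
Compound 3, `CCOC(=O)Nc1ccc([Se][Se]c2ccc(NC(=O)OCC)cc2)cc1`: 49500 nM

All three were tested in a functional assay on CCRF-CEM cells (Homo sapiens) for cytotoxicity, read by MTT assay, with a stated time of 72 h; a higher number here means a weaker inhibitor of growth, a lower number a stronger inhibitor of growth. Compound 1 and compound 3 each carry two linked units built around the same shared core, while compound 2 is a single such unit with a propyl group on the oxygen of its carbamate. Among the three numbers, compound 2 has the lowest, but its gap to compound 1 and its gap to compound 3 both fall within the usual scatter of this assay, so the three compounds cannot be separated on these measurements.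

The next compound, compound 4, is `N#C[Se]c1ccc(NC(=O)Oc2ccccc2)cc1`. It differs from compound 2 in one place: phenyl in place of propyl on an oxygen next to a carbonyl group. Going by the values given here, no measured pair in this set shows what such a swap does, so there is no step to lean on. Given that all three values so far sit close together, the expectation is for no change beyond the scatter, with the number for compound 4 staying near that of compound 2.

The estimated step in this assay from a 1.1-fold lower number from compound 2 to compound 4 (0.04 log units; within the scatter) is expected to be small. Compound 4 is therefore expected to give about 35000 nM, in a range from 15000 nM to 90000 nM.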

Compound 4, concentration for total growth inhibition: 48000 nM
Compound 4: middle estimate off by 1.4-fold (0.14 log units), on the low side, and the stated range covers the measured number.
By their numbers in this assay, from the lowest: compounds 2, 1, 4 and 3 (each within the scatter of the next).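

In this assay, going by these compounds alone, the swap of phenyl in place of propyl on an oxygen next to a carbonyl group gives a 1.3-fold higher number from compound 2 to compound 4 (0.10 log units; within the scatter), and this is the first comparison in the set between compounds that differ in one place. The earlier compounds shown here differed in more than one place, so they could not isolate the group on this oxygen. This single pair now shows that an aromatic ring and a short open chain at this position give numbers that the assay cannot separate, so the swap leaves growth inhibition without a detectable change. No measurement shown here offers an explanation for this result.

From the compounds shown here alone, with only propyl and phenyl compared directly, it remains open whether any other group on this oxygen would move the number beyond the scatter, such as a longer chain, or a phenyl ring carrying an amine or a carboxylic acid. It also remains open what joining two units does on its own, since neither compound 1 nor compound 3 shares its carbamate group with a single-unit partner among these compounds.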